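Swapping one end group on compound 1

The source may hold more compounds than are shown below. What is called first, only, known or untested is meant among the compounds shown, and "the series" means these compounds.

Compound 1 `COc1ccc(CN(C(=O)Cn2cc(COc3ccc4ccc(=O)oc4c3)nn2)c2cc(OC)c(OC)c(OC)c2)cc1`: 860 nM
Compound 2 `COc1ccc(CN(C(=O)Cn2cc(CSc3nnc(-c4ccccc4)c(-c4ccccc4)n3)nn2)c2cc(OC)c(OC)c(OC)c2)cc1`: 19600 nM

In a functional assay on PC-3 cells (Homo sapiens) for antiproliferative activity, read by MTT assay, with a stated time of 48 h (on this read-out lower numbers stand for stronger inhibition and higher numbers for weaker inhibition), compound 1 has the lower of the two numbers, which means the stronger inhibition. Compound 2 sits much higher, a gap beyond the usual scatter of repeated measurements.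

Compound 3 `COc1ccc(CN(C(=O)Cn2cc(CSc3nncs3)nn2)c2cc(OC)c(OC)c(OC)c2)cc1` has not been measured yet. It keeps the shared core of compound 1 and changes one group, on a saturated chain carbon bound to an aromatic carbon: a group of 6 heavy atoms (2 carbon, 2 nitrogen, 2 sulfur; one five-membered aromatic ring with 3 hetero atoms) in place of a group of 12 heavy atoms (9 carbon, 3 oxygen; one six-membered aromatic ring of carbon only, one six-membered aromatic ring with 1 hetero atom), on a saturated chain carbon bound to an aromatic carbon. The incoming (1,3,4-thiadiazol-2-yl)sulfanyl group is the smaller of the two. Among the compounds with values here, no measured pair shows this exact change, so the only guide is the wide spread of the two values, and the expectation is uncertain. The number is expected to rise beyond the scatter, and the estimated step is a 4.7-fold higher number from compound 1 to compound 3 (0.67 log units; beyond the scatter). For compound 3 the expected value is 4000 nM, with an estimated range of 1000 nM to 16000 nM.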

Compound 3, half-maximal inhibitory concentration: 16500 nM
Compound 3: middle estimate off by 4.1-fold (0.62 log units), on the low side, outside the stated range (above it).
By their numbers in this assay, from the lowest: compound 1; then compounds 3 and 2 (each within the scatter of the next).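

In this assay, replacing the group of 12 heavy atoms with the smaller (1,3,4-thiadiazol-2-yl)sulfanyl group, on a saturated chain carbon bound to an aromatic carbon, gives a 19-fold higher number from compound 1 to compound 3 (1.28 log units; beyond the scatter). Within the data shown here, this is the first single-place step at this position, and it shows that the low number of compound 1 does not survive this exchange. Nothing measured here explains the rise, so the data show its size but not its cause.

The exchange alters the ring system and the atom linking it to the chain at once, so the compounds shown cannot separate the two changes. As far as these compounds go, whether the number stays low with a plain phenoxy group, or rises with a simple amine, remains open.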